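Chloro on the Phenol Ring of a Pyridyl Ketone

The source may report more compounds than this note shows. Statements on the series, on what has been measured and on what is new or still open speak of the compounds shown alone.

Measured compounds:
Compound 1 `O=C(c1cccnc1)c1ccccc1O` gives 33400 nM
Compound 2 `O=C(c1cccnc1)c1ccc(Br)cc1O` gives 88600 nM
Compound 3 `O=C(c1cccnc1)c1cccc(Cl)c1O` gives 31500 nM

In a functional assay on PC-3 cells (Homo sapiens) for cytotoxicity, read by sulforhodamine B assay, with a stated time of 48 h (on this read-out lower numbers stand for stronger inhibition and higher numbers for weaker inhibition), compound 1 stands second highest of the three numbers; compound 3 lies nearest, and compound 2 furthest from it. Compound 4 `O=C(c1cccnc1)c1cc(Cl)ccc1O` is not yet measured in this assay. It differs from compound 1 in one place: chloro in place of hydrogen on an aromatic carbon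

Going by the values given here, two measured steps bear on this change. Both swap a halogen for hydrogen on an aromatic carbon of the same ring, though neither at the very place where compound 4 carries its chloro. The step of a 2.7-fold higher number from compound 1 to compound 2 (0.42 log units; beyond the scatter) is a modest move beyond the scatter toward a weaker read-out. The step of a 1.1-fold lower number from compound 1 to compound 3 (0.03 log units; within the scatter) stays within the scatter. A chloro thus left the number essentially unchanged at one place, while a bromo at another raised it modestly. Compound 4 is therefore expected to sit close to compound 1, with at most a small drift toward a higher number, an expected step of a 1.2-fold higher number from compound 1 to compound 4 (0.08 log units; within the scatter). For compound 4 the estimate in this assay is 40000 nM, with a range from 18000 nM to 90000 nM.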

Compound 4, half-maximal inhibitory concentration: 24800 nM
Estimate against measurement, compound 4: 1.6-fold (0.21 log units) above, within the range that was stated.
By their numbers in this assay, from the lowest: compounds 4, 3 and 1 (each within the scatter of the next); then compound 2.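

In this assay, chloro on the aromatic carbon para to the hydroxy group and meta to the group of 8 heavy atoms gives a 1.3-fold lower number from compound 1 to compound 4 (0.13 log units; within the scatter) and so stays within the scatter, which means this position does not separate compound 4 from compound 1 on this read-out. Taken with a 1.1-fold lower number from compound 1 to compound 3 (0.03 log units; within the scatter) as a second chloro step within the scatter, it shows that chloro in place of hydrogen falls within the scatter at two different places on this ring, whereas a 2.7-fold higher number from compound 1 to compound 2 (0.42 log units; beyond the scatter) with a bromo goes against any general rule for halogens there by lying beyond it. No measurement is available that would explain why these steps differ in size.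

The compounds shown leave open whether the step beyond the scatter belongs to the bromo itself or to the place it occupies, since no bromo stands at either chloro position and no chloro stands at the bromo position. They also leave open how an amine, a carboxylic acid or a longer chain would read at the position para to the hydroxy group.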